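A few compounds are considered here, and "the series" means these few. Any claim that something is new, unique, unknown or untested is made for them only; others in the source may bear on it.

Working notes on the series. Compound 1 `COc1cc(C2=C(c3cc(C)c(OC)c(C)c3)C(O)CC2=O)cc(OC)c1OC` and compound 2 `COc1cc(C2=C(c3cc(C)c(OC)c(C)c3)C(OC(C)=O)CC2=O)cc(OC)c1OC` share one core; compound 3 `COc1ccc(C2=C(c3cc(OC)c(OC)c(OC)c3)C(=O)C(O)C2)cc1Cl` carries a core that differs from that of compound 1 in more than one place, and the difference between the two cores is not broken down here. Compound 4 `COc1ccc(C2=C(c3cc(OC)c(OC)c(OC)c3)C(=O)C(OC(C)=O)C2)cc1Cl` stands to compound 3 as compound 2 stands to compound 1.

In an ADME assay on HEK293 cells (Homo sapiens) for cytotoxicity, read by MTT assay, with a stated time of 72 h (on this read-out higher numbers stand for weaker inhibition and lower numbers for stronger inhibition), compound 1 gives > 100 ug/mL, which is a limit of the assay and not a number. In this assay compound 2 gives > 100 ug/mL, again a limit. In this assay compound 3 gives > 100 ug/mL, also a limit. The change from compound 1 to compound 2 is acetyl in place of hydrogen on an oxygen on a saturated carbon; the step it made, a step that the two limits leave unreadable from compound 1 to compound 2, cannot be read because the limit of > 100 ug/mL in this assay, at which 3 of the 3 values shown sit, covers both ends of it. The change from compound 3 to compound 4 is acetyl in place of hydrogen on an oxygen on a saturated carbon, the same change at a place described in the same words, so it counts as the same change.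

Going by the values given here, the step that the limit leaves unreadable from compound 3 to compound 4 is expected to be small because the limit of > 100 ug/mL in this assay, at which 3 of the 3 values shown sit, holds every value so far, the one known instance of this change included, and gives no sign of a move in either direction. In this assay compound 4 is expected to give 150 ug/mL, most probably reported once more only as a limit rather than a number.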

Compound 4, half-maximal inhibitory concentration: 60 ug/mL
For compound 4 the middle estimate is 2.5-fold (0.40 log units) above the measured one; the range from low to high includes it.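

In this assay, acetyl in place of hydrogen on an oxygen on a saturated carbon gives, on the core of compound 3, an at least 1.6-fold lower number from compound 3 to compound 4 (0.22 log units; that floor lies within the scatter); only the floor of this step is known, and with that floor inside the scatter the step alone does not establish a real shift. The same change on the core of compound 1 cannot be read, and neither carry-over of the step from one core to the other nor its failure is shown, because both ends of that pair sit at the limit: the limit of > 100 ug/mL in this assay, at which 3 of the 4 values shown sit. Compound 4 is the only compound here with a number rather than a limit, but the cores of compound 1 and compound 3 differ in more than one place, and no part of this outcome can be assigned to either core.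

The compounds shown leave open how a longer acyl chain such as butanoyl, a methyl ether, an amine or a carboxylic acid in this place would read on either core. As far as these compounds go, the full size of the step on the core of compound 3 also stays open, with only a limit at its starting end.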